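Aryl variation on the shared core: methoxyphenyl analogue

The source may hold more compounds than are shown below. What is called first, only, known or untested is meant among the compounds shown, and "the series" means these compounds.

Measured so far:
compound 1 `CC#CC(CC(=O)O)c1ccc(OCc2ccc3nc(-c4ccc(CC)cc4)cn3c2)cc1` 496 nM
compound 2 `CC#CC(CC(=O)O)c1ccc(OCc2ccc3nc(-c4ccccc4C)cn3c2)cc1` 389 nM

Compound 2 holds the lowest of the two numbers in an assay on isolated protein for agonist activity at Free fatty acid receptor 1 (Homo sapiens); on this read-out higher numbers stand for an effect only at larger amounts of compound and lower numbers for an effect already at smaller amounts; compound 1 stands nearest, and the step of a 1.3-fold lower number from compound 1 to compound 2 (0.11 log units; within the scatter) lies within the scatter. Compound 3 `CC#CC(CC(=O)O)c1ccc(OCc2ccc3nc(-c4ccc(OC)cc4)cn3c2)cc1` differs by 4-methoxyphenyl in place of 2-methylphenyl on an aromatic carbon. Among the measured compounds shown here, the only step that bears on this aryl position is a 1.3-fold lower number from compound 1 to compound 2 (0.11 log units; within the scatter), which showed no change beyond the scatter. For compound 3 in this assay a step of a 1.1-fold higher number from compound 2 to compound 3 (0.03 log units; within the scatter) is expected, none beyond the scatter. The estimate for compound 3 is 420 nM (range 180 nM to 980 nM).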

Compound 3, half-maximal effective concentration: 47 nM
For compound 3 the middle estimate is 8.9-fold (0.95 log units) above the measured one; the measured number lies below the stated range.
By their numbers in this assay, from the lowest: compound 3; then compounds 2 and 1 (each within the scatter of the next).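

This aryl position, where the first two groups gave no difference beyond the scatter, does respond in this assay: 4-methoxyphenyl gives an 8.3-fold lower number from compound 2 to compound 3 (0.92 log units; beyond the scatter) on replacing 2-methylphenyl, and an 11-fold lower number from compound 1 to compound 3 (1.02 log units; beyond the scatter) with methoxy in place of ethyl on the otherwise unchanged phenyl. The larger of these steps therefore comes from a single change of substituent on the phenyl, from ethyl to methoxy. Nothing available accounts for this gain.

Open, going by these compounds, is how other groups in place of methoxy would fare, such as ethoxy, hydroxy or an amine. Also open, on these data alone, is whether the gain would hold for a longer alkoxy chain.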